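From Compound 3 to Compound 4 at the Substance-P Receptor

The source may hold more compounds than are shown below. What is called first, only, known or untested is meant among the compounds shown, and "the series" means these compounds.

Compound 3 `C[C@@H](O[C@H]1CN2C(=O)C=C(c3cc[n+]([O-])cc3)CC2[C@@H]1c1ccc(F)cc1)c1cc(C(F)(F)F)cc(C(F)(F)F)c1` gives 0.1 nM in an assay on CHO cells for displacement of a labelled ligand from Substance-P receptor (Homo sapiens) (a higher number here means a weaker inhibitor, a lower number a stronger inhibitor), the lowest of the three numbers measured. Compound 1 `C[C@@H](O[C@H]1CN2C(=O)C=C(c3ccccc3)CC2[C@@H]1c1ccc(F)cc1)c1cc(C(F)(F)F)cc(C(F)(F)F)c1` gives 0.93 nM, and compound 2 `C[C@@H](O[C@H]1CN2C(=O)C=C(c3ccc(C#N)cc3)CC2[C@@H]1c1ccc(F)cc1)c1cc(C(F)(F)F)cc(C(F)(F)F)c1` gives 1.8 nM. Compound 4 `Cc1cc(C2=CC(=O)N3C[C@H](O[C@H](C)c4cc(C(F)(F)F)cc(C(F)(F)F)c4)[C@@H](c4ccc(F)cc4)C3C2)ccn1` carries a group of 7 heavy atoms (6 carbon, 1 nitrogen; one six-membered aromatic ring with 1 hetero atom) in place of a group of 7 heavy atoms (5 carbon, 1 nitrogen, 1 oxygen; one six-membered aromatic ring with 1 hetero atom), on a double-bonded ring carbon. For the measured compounds named here, no measured step makes this exact change. The nearest are a 9.3-fold lower number from compound 1 to compound 3 (0.97 log units; beyond the scatter) and an 18-fold lower number from compound 2 to compound 3 (1.26 log units; beyond the scatter), both obtained by replacing a six-membered carbon-only aromatic ring with the ring that leaves here, while a 1.9-fold higher number from compound 1 to compound 2 (0.29 log units; within the scatter) shows that adding cyano on that carbon-only ring stayed within the scatter. Compound 4 is therefore expected to give back part of that gain, a step of a 4.0-fold higher number from compound 3 to compound 4 (0.60 log units; beyond the scatter) in this assay. Compound 4 is estimated at 0.4 nM, with a range of 0.1 nM to 1.6 nM.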

Compound 4, half-maximal inhibitory concentration: 0.51 nM
For compound 4 the middle estimate is 1.3-fold (0.11 log units) below the measured one; low and high end bracket the measured number.
By their numbers in this assay, from the lowest: compound 3; then compounds 4, 1 and 2 (each within the scatter of the next, the first and the last beyond it).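

In this assay the 2-methylpyridin-4-yl group on this double-bonded ring carbon does not keep the full level of the ring in compound 3, a step of a 5.1-fold higher number from compound 3 to compound 4 (0.71 log units; beyond the scatter) in this series. Measured against the carbon-only rings, it gives a 3.5-fold lower number from compound 2 to compound 4 (0.55 log units; beyond the scatter) when it replaces 4-cyanophenyl, but a 1.8-fold lower number from compound 1 to compound 4 (0.26 log units; within the scatter) when it replaces phenyl. A nitrogen-containing ring at this position therefore does not by itself reproduce the low number of compound 3.

No evidence given here accounts for these steps.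

The compounds shown leave open how much of the step belongs to the methyl group and how much to the lost ring oxygen, a question that the plain pyridin-4-yl group would address.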